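Cytotoxicity of Thiadiazole Anilides: Dechlorination Step Assessed

A few compounds are considered here, and "the series" means these few. Any claim that something is new, unique, unknown or untested is made for them only; others in the source may bear on it.

Of the compounds shown here, three have been measured in an ADME assay on HepG2 cells (Homo sapiens) for cytotoxicity, with a stated time of 3 days; a lower number here means that less compound is tolerated, a higher number that more compound is tolerated. Compound 1 `CC(Sc1nnc(-c2ccncc2)s1)C(=O)Nc1ccc(Cl)cc1Cl` gives only a limit of the assay, > 50000 nM. Compound 2 `CC(Sc1nnc(-c2ccncc2)s1)C(=O)Nc1ccccc1Cl` likewise gives only a limit, > 50000 nM. Compound 3 `O=C(CCSc1nnc(-c2ccncc2)s1)Nc1ccc(Cl)cc1` gives a number, 7260 nM. The change between compound 1 and compound 2 is hydrogen in place of chloro on an aromatic carbon, and it produces a step that the two limits leave unreadable from compound 1 to compound 2; its size cannot be read, given (the limit of > 50000 nM in this assay, at which 2 of the 3 values shown sit). How the core of compound 3 differs from the core of compound 1 is not broken down here.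

Compound 4 `O=C(CCSc1nnc(-c2ccncc2)s1)Nc1ccccc1` is not yet measured in this assay. It arises from compound 3 by hydrogen in place of chloro on an aromatic carbon. This is the same kind of change as that from compound 1 to compound 2, but the surroundings differ: in the earlier pair the carbon bearing the chloro is also meta to a chloro group, whereas in compound 3 it is not. Since the earlier step is unreadable, the expectation for compound 4 rests only on the value of compound 3, 7260 nM. The step from compound 3 to compound 4 is estimated at a 1.7-fold higher number from compound 3 to compound 4 (0.22 log units; within the scatter). Compound 4 is therefore expected to give about 12000 nM, estimated between 4000 nM and 50000 nM.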

Compound 4, half-maximal cytotoxic concentration: > 50000 nM
Compound 4 gave a limit, no number (the forecaster's own chance of this, stated with the estimate: 25%); at least 4.1-fold (0.61 log units) between middle value and limit.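

In this assay, the change from the 4-chlorophenyl to the phenyl, hydrogen in place of chloro on an aromatic carbon, gives an at least 6.8-fold higher number from compound 3 to compound 4 (0.83 log units; beyond the scatter), and this size is only a minimum, as compound 4 gives a limit of the assay and not a number. The change therefore has a readable effect on the core of compound 3, the only place in this series where it can be sized. It does not show that the effect carries from one core to another, as the same change on the core of compound 1 cannot be read, leaving no second step to set beside this one, because both of its compounds stand at a limit: the limit of > 50000 nM in this assay, at which 3 of the 4 values shown sit.

From the compounds shown here alone, how far beyond its limit compound 4 lies remains open, and so does how the core of compound 1 responds to the loss of a chloro. Also open, going by these compounds, is whether an amine or a fluoro in the place of the chloro, or a longer chain on the sulfur, would follow compound 3 or compound 4.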